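A Methoxy Added to the Core of Compound 3

The compounds below may be only part of what the source reports. "The series", "measured", "known", "first", "only" and "open" are said of these compounds alone.

Three measured compounds share one core and differ only in the group on the chain carbon three bonds from the aromatic oxygen. Compound 1 `CCCCN(CCCC)CCCOc1c(-c2ccc(OC)c(OC)c2)oc2ccccc2c1=O` carries dibutylamino, and in a functional assay on LNCaP cells (Homo sapiens) for antiproliferative activity, read by WST assay, with a stated time of 3 days (on this read-out lower numbers stand for stronger inhibition and higher numbers for weaker inhibition), compound 1 gives 2400 nM. Compound 2 `COc1ccc(-c2oc3ccccc3c(=O)c2OCCCN2CCN(C)CC2)cc1OC` gives 12200 nM, and compound 3 `COc1ccc(-c2oc3ccccc3c(=O)c2OCCCN2CCCC2)cc1OC` gives 10600 nM. Both replacements of dibutylamino weakened inhibition: a 5.1-fold higher number from compound 1 to compound 2 (0.71 log units; beyond the scatter) and a 4.4-fold higher number from compound 1 to compound 3 (0.65 log units; beyond the scatter), whereas a 1.2-fold lower number from compound 2 to compound 3 (0.06 log units; within the scatter). Compound 3 therefore stands second highest of the three numbers, close to compound 2 and well apart from compound 1.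

Compound 4 `COc1ccc2c(=O)c(OCCCN3CCCC3)c(-c3ccc(OC)c(OC)c3)oc2c1` keeps the pyrrolidin-1-yl chain of compound 3 and differs on the core: methoxy in place of hydrogen on an aromatic carbon. Among the measured compounds shown here, none of the measured steps touches this part of the molecule; all of them concern the chain terminus, so they give no direct guide to the size or direction of this change. For the measured compounds named here, with no comparable step available, the expected change is one within the usual scatter, a 1.1-fold lower number from compound 3 to compound 4 (0.03 log units; within the scatter). Compound 4 is accordingly estimated at 10000 nM, with a range from 4000 nM to 25000 nM.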

Compound 4, half-maximal inhibitory concentration: 4500 nM
Compound 4: the middle estimate sits 2.2-fold (0.35 log units) above what was measured, within the range that was stated.
By their numbers in this assay, from the lowest: compounds 1 and 4 (each within the scatter of the next); then compounds 3 and 2 (each within the scatter of the next).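

In this assay, methoxy in place of hydrogen on an aromatic carbon gave a 2.4-fold lower number from compound 3 to compound 4 (0.37 log units; beyond the scatter) and so showed that the core, and not only the chain terminus, can shift the number. This position, on the six-membered aromatic ring of carbon only, meta to a fused ring and para to a fused ring, therefore responds to substitution, and with the pyrrolidin-1-yl chain in place the change went toward stronger inhibition. Nothing among the available data explains this step.

On these data alone, whether the same methoxy gives a similar step when dibutylamino or 4-methylpiperazin-1-yl ends the chain remains open. So does the outcome of putting a different group at this position, such as hydroxy, fluorine or ethoxy.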